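A few compounds are considered here, and "the series" means these few. Any claim that something is new, unique, unknown or untested is made for them only; others in the source may bear on it.

Compound 1 `COc1ccccc1-c1cc(/C=C/c2ccc(C(=O)NO)cc2)ccn1`: 8440 nM
Compound 2 `O=C(NO)c1ccc(/C=C/c2ccnc(-c3cccnc3)c2)cc1`: 5140 nM

Among the compounds with values here, both numbers come from a functional assay on HCT-116 cells (Homo sapiens) for antiproliferative activity, read by CellTiter-Glo, with a stated time of 72 h (a lower number here means a stronger inhibitor, a higher number a weaker inhibitor), and no other compound has been measured in it so far. Within the data shown here, compound 2 therefore stands level with the only other measured compound. Among the measured compounds shown here, the single measured step is a 1.6-fold lower number from compound 1 to compound 2 (0.22 log units; within the scatter) with pyridin-3-yl in place of 2-methoxyphenyl on an aromatic carbon.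

Compound 3 `O=C(NO)c1ccc(/C=C/c2ccnc(-c3ccc(F)cc3)c2)cc1` differs from compound 2 at that same carbon, next to the ring nitrogen, with 4-fluorophenyl in place of pyridin-3-yl on an aromatic carbon and the rest of the structure stays the same. For the measured compounds named here, the only guide is that earlier exchange at this carbon, which left compound 2 at 5140 nM and so within the scatter of compound 1. One step is thin evidence, and it gives no direction. No change beyond the scatter is therefore expected, and the estimated step is a 1.0-fold lower number from compound 2 to compound 3 (0.01 log units; within the scatter) on that basis. For compound 3 the estimated value is 5000 nM and the expected range runs from 2000 nM to 12000 nM.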

Compound 3, half-maximal inhibitory concentration: > 10000 nM
Compound 3: a limit, no number (the forecaster's own chance of this, stated with the estimate: 8%); middle value at least 2.0-fold (0.30 log units) away from the limit.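

In this assay compound 3 gives > 10000 nM, which is a limit of the assay and not a number. At this carbon next to the ring nitrogen, the exchange gives an at least 1.9-fold higher number from compound 2 to compound 3 (0.28 log units; that floor lies within the scatter), and the exchange of the other carbon-only ring gives an at least 1.1-fold higher number from compound 1 to compound 3 (0.07 log units; that floor lies within the scatter). Both floors lie within the scatter, so neither step establishes a real loss and the three rings cannot be put in order, but this position has now produced a result that leaves the readable range of the assay, which neither earlier exchange did, and compound 1, which also carries a ring of carbon only, goes against any reading that the ring nitrogen alone decides the outcome: what can be said of compound 3 ends at the ceiling of the assay: the limit of > 10000 nM in this assay, at which 1 of the 3 values shown sits.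

The compounds shown leave open how far compound 3 really lies from compound 2, and so whether the exchange matters at all. They also leave open what this carbon does with something other than an aromatic ring, such as an amine, a carboxylic acid or a short alkyl chain.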